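A few compounds are considered here, and "the series" means these few. Any claim that something is new, unique, unknown or untested is made for them only; others in the source may bear on it.

Measured compounds:
Compound 1, `CNc1nc2cc(Cl)c(Cl)cc2n1COCCO` — in a functional assay on KB cells (Homo sapiens) for inhibition (a lower number here means a stronger inhibitor, a higher number a weaker inhibitor), compound 1 gives > 100000 nM, a limit of the assay and not a number.
Compound 2, `Nc1nc2c(Cl)cc(Cl)cc2n1COCCO` — in this assay compound 2 gives > 100000 nM, which is likewise a limit of the assay and not a number.

Going by the values given here, both values that have been recorded sit at the same limit, (the limit of > 100000 nM in this assay, at which 2 of the 2 values shown sit), so nothing in the set places compound 2 anywhere other than at that limit; no measured step between compounds that differ in a single place exists in this set.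

The next compound follows from compound 2 by a single change: compound 3, `CNc1nc2c(Cl)cc(Cl)cc2n1COCCO`, carries methyl in place of hydrogen on a nitrogen on an aromatic ring. Among the compounds with values here, no measured step of this kind is available, and compound 1, which also carries a methylamino group on its core, offers only a limit in this assay. The account therefore expects no step beyond the scatter, in either direction, and expects that compound 3 will most likely again return only a limit.

The expected step from compound 2 to compound 3 is a step that the limit leaves unreadable from compound 2 to compound 3. Compound 3 is estimated at 200000 nM, with a range from 50000 nM to 1000000 nM.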

Compound 3, half-maximal inhibitory concentration: > 100000 nM
Compound 3 gave a limit, no number (the forecaster's own chance of this, stated with the estimate: 85%); the middle value lies beyond the limit too.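

In this assay compound 3 gives > 100000 nM, a limit of the assay and not a number. No step can be read from compound 2 to compound 3, as both stand at the same limit: the limit of > 100000 nM in this assay, at which 3 of the 3 values shown sit. The compounds shown leave open how strongly any of them inhibits, and whether methyl in place of hydrogen on that nitrogen changes this at all.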